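The source may report more compounds than this note shows. Statements on the series, on what has been measured and on what is new or still open speak of the compounds shown alone.

Measured so far in an ADME assay on the whole organism for pharmacokinetics, with Homo sapiens as the target; a lower number here means that a smaller share of the oral dose reaches the circulation, a higher number that a larger share of the oral dose reaches the circulation:
compound 1 `COc1ccccc1NS(=O)(=O)c1ccc2nc(-c3ccccc3)c(-c3ccccc3)nc2c1` gives 100%;
compound 2 `O=[N+]([O-])c1ccc(NS(=O)(=O)c2ccc3nc(-c4ccccc4)c(-c4ccccc4)nc3c2)cc1` gives 87.6%.

Of these two numbers, compound 2 holds the lower one. For the measured compounds named here, the one step measured so far, a number 12.4 percentage points lower from compound 1 to compound 2 (beyond the scatter), arose from 4-nitrophenyl in place of 2-methoxyphenyl on a sulfonamide nitrogen.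

Compound 3 `O=C(NS(=O)(=O)c1ccc2nc(-c3ccccc3)c(-c3ccccc3)nc2c1)c1ccccc1` has not yet been measured. Its difference from compound 2 is benzoyl in place of 4-nitrophenyl on a sulfonamide nitrogen. The measured step touches the same sulfonamide nitrogen but exchanges one aryl group for another, whereas here an aryl group gives way to benzoyl, so it bears on the question only loosely. Going by the values given here, it shows that changes at this position so far have moved this assay modestly, with compound 1 and compound 2 both lying high. The step from compound 2 to compound 3 is therefore expected to be small or none beyond the scatter, a number 7.6 percentage points lower from compound 2 to compound 3 (within the scatter), and compound 3 is estimated at 80%, with a range from 55% to 100%.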

Compound 3, oral bioavailability: 100%
Compound 3: the middle estimate sits 20 percentage points below what was measured, within the range that was stated.
By their numbers in this assay, from the lowest: compound 2; then compounds 1 and 3 (each within the scatter of the next).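

Benzoyl in place of 4-nitrophenyl on the sulfonamide nitrogen gave a number 12.4 percentage points higher from compound 2 to compound 3 (beyond the scatter) in this assay, so a high number at this position does not depend on an aryl group sitting directly on that nitrogen. Set against 2-methoxyphenyl, the same benzoyl group gave no change at the digits printed from compound 1 to compound 3 (within the scatter), which leaves compound 2, with its 4-nitrophenyl group, as the only one of the three apart from the others, while compound 1 and compound 3 cannot be ordered. Nothing available on these compounds accounts for this difference.

As far as these compounds go, all three groups on this nitrogen carry a six-membered aromatic ring of carbon only, so it stays open how an acetyl group, a longer alkyl chain or a carboxylic acid would read in this assay. An unsubstituted phenyl on the same nitrogen would be needed to tell whether the nitro group itself goes with the lower number.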